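A few compounds are considered here, and "the series" means these few. Any claim that something is new, unique, unknown or untested is made for them only; others in the source may bear on it.

Measured compounds:
compound 1, `CCCCCn1c(CCC)nc2cc(NS(C)(=O)=O)ccc21`: 86.4%
compound 2, `CCCCCCn1c(CCC)nc2cc(NS(C)(=O)=O)ccc21`: 86.4%

In a functional assay on the whole organism with Rattus norvegicus as the target, read by paw edema, with a stated time of 5 h, at a dose of 10 mg/kg by the oral route (on this read-out lower numbers stand for a weaker effect and higher numbers for a stronger effect at the one dose given), compound 2 gives 86.4%, level with compound 1 at the digits reported; the step of no change at the digits printed from compound 1 to compound 2 (within the scatter) lies within the scatter. Compound 3, `CCCCn1c(CCC)nc2cc(NS(C)(=O)=O)ccc21`, is not yet measured. It differs from compound 2 by hydrogen in place of ethyl on a saturated chain carbon, four bonds along the chain from an aromatic nitrogen. Within the data shown here, only the step from compound 1 to compound 2 bears on this change, and it showed no movement; it also ran in the opposite sense, lengthening rather than shortening the chain, so it is a guide of limited reach. Compound 3 is therefore expected to show no step beyond the scatter, a number 2.4 percentage points lower from compound 2 to compound 3 (within the scatter). The estimate for compound 3 is 84%, between 70% and 93%.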

Compound 3, a percentage reported as activity, at one dose (the size of the read-out at that dose, not a potency): 86.4%
Beside the measured number, compound 3's estimate is 2.4 percentage points below it, and the stated range covers the measured number.
By their numbers in this assay, from the lowest: compounds 1, 2 and 3 (each within the scatter of the next).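

In this assay hydrogen in place of ethyl, four bonds along the chain from an aromatic nitrogen, gives no change at the digits printed from compound 2 to compound 3 (within the scatter) and hydrogen in place of methyl at that place gives no change at the digits printed from compound 1 to compound 3 (within the scatter) on the same read-out. The chain on the aromatic nitrogen now reads flat on shortening as well as on lengthening, across the three compounds shown. Nothing measured here accounts for this flatness. Still open, from the compounds shown here alone, is whether a methyl on that nitrogen, or an amine or carboxylic acid at the chain end, would hold this level.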